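Sulfonyl-substituent change in a K562 growth-inhibition series

This account rests on a few compounds, and the source may have more. Where it says the series, first, only, none or still open, it means among the compounds named here.

Of the compounds shown here, two carry numbers so far. Compound 1 `Cn1c(=O)c(S(=O)(=O)c2ccc(F)cc2F)cc2cnc(Nc3ccc4cc[nH]c4c3)nc21` gives 5000 nM in a functional assay on K562 cells (Homo sapiens) for inhibition, read by trypan blue exclusion, with a stated time of 72 h; a lower number here means a stronger inhibitor, a higher number a weaker inhibitor. For the measured compounds named here, compound 2 `Cn1c(=O)c(S(=O)(=O)Cc2ccc(F)cc2F)cc2cnc(Nc3ccc4[nH]ccc4c3)nc21` gives 1000 nM in this assay, the lowest of the two numbers; the gap to compound 1 lies beyond the scatter, and no single-point step connects the two, so the pair shows only that compound 2 returns the lower figure.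

Compound 3 `Cn1c(=O)c(S(=O)(=O)c2ccc(C(=O)O)cc2)cc2cnc(Nc3ccc4[nH]ccc4c3)nc21` is not yet measured. It differs from compound 2 in one place: 4-carboxyphenyl in place of 2,4-difluorobenzyl on a sulfonyl sulfur.

Going by the values given here, the set holds no measured step for this kind of exchange, so the size of the effect rests on expectation alone. Among the compounds with values here, compound 3 is expected to move toward a higher number in this assay, by a step of a 3.0-fold higher number from compound 2 to compound 3 (0.48 log units; beyond the scatter) that is moderate and probably beyond the scatter, because compound 1 gives 5000 nM and so lies well above compound 2 as the only other number in the set. Compound 3 is therefore estimated at 3000 nM, with a range from 800 nM to 12000 nM.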

Compound 3, half-maximal inhibitory concentration: 5000 nM
Compound 3: the middle estimate sits 1.7-fold (0.22 log units) below what was measured; measured number inside the range.
By their numbers in this assay, from the lowest: compound 2; then compounds 1 and 3 (each within the scatter of the next).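

In this assay, for the compounds shown here, the exchange of 2,4-difluorobenzyl for 4-carboxyphenyl on a sulfonyl sulfur gives the first readable single-place step, a 5.0-fold higher number from compound 2 to compound 3 (0.70 log units; beyond the scatter), so the number does respond to the group at this position. Going by these compounds alone, the step bundles more than one structural difference: the fluorine atoms leave, a carboxylic acid enters, and the benzyl group gives way to a phenyl ring, with only the entering group carrying a hydrogen-bond donor and acceptor, so the single step cannot assign its size to any one of these differences. The notes hold no independent measurement that accounts for this step.

The compounds shown leave open whether the higher number follows the loss of the benzyl group or the arrival of the carboxylic acid, a question that 4-carboxybenzyl or an unsubstituted phenyl on the same sulfonyl sulfur would address. Also open, as far as these compounds go, is whether the acid itself matters, which a methyl ester or a primary amide in its place would test.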